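Side-chain lengthening in the hydroxyalkyl quinone series

The compounds below may be only part of what the source reports. "The series", "measured", "known", "first", "only" and "open" are said of these compounds alone.

Compound 2 `CCC(O)C1=CC(=O)c2c(OC)ccc(OC)c2C1=O` gives 0.516 ug/mL in a functional assay on L1210 cells (Mus musculus) for cytotoxicity (a lower number here means that less compound is needed, a higher number that more compound is needed for the effect), the highest of the three numbers in hand. Compound 1 `COc1cc(C(C)O)c(OC)c2c1C(=O)C=CC2=O` gives 0.132 ug/mL in this assay, and compound 3 `CCC(O)c1cc(OC)c2c(c1OC)C(=O)C=CC2=O` gives 0.085 ug/mL; both stand beyond the scatter from compound 2, compound 1 the nearer and compound 3 the further. Compound 4 `CCCCCCC(O)C1=CC(=O)c2c(OC)ccc(OC)c2C1=O` is not yet measured. It differs from compound 2 by butyl in place of hydrogen on a saturated chain carbon, three bonds along the chain from a double-bonded ring carbon and an oxygen on a saturated carbon, which, cut one bond further out, reads as 1-hydroxypropyl to 1-hydroxyheptyl.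

Among the compounds with values here, the only measured step that concerns lengthening of this chain is a 1.6-fold lower number from compound 1 to compound 3 (0.19 log units; within the scatter), where methyl replaced hydrogen two bonds along the chain from an aromatic carbon; that step was small and within the scatter. It was made on a core where the chain hangs from an aromatic carbon, whereas in compound 2 and compound 4 the chain hangs from a double-bonded ring carbon, so it is only a partial guide. Within the data shown here, what enters here is butyl rather than methyl, and no step of that size on this chain has been measured. The expectation is therefore for a step of no more than modest size in this assay, a 1.3-fold lower number from compound 2 to compound 4 (0.11 log units; within the scatter), most likely within the scatter and, if anything, toward a lower number. Compound 4 is expected to give about 0.4 ug/mL, with a range from 0.12 ug/mL to 1.3 ug/mL.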

Compound 4, concentration for half-maximal effect: 0.732 ug/mL
For compound 4 the middle estimate is 1.8-fold (0.26 log units) below the measured one; low and high end bracket the measured number.
By their numbers in this assay, from the lowest: compounds 3 and 1 (each within the scatter of the next); then compounds 2 and 4 (each within the scatter of the next).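

In this assay, butyl in place of hydrogen on a saturated chain carbon, three bonds along the chain from a double-bonded ring carbon and an oxygen on a saturated carbon, gives a 1.4-fold higher number from compound 2 to compound 4 (0.15 log units; within the scatter), so the change from 1-hydroxypropyl to 1-hydroxyheptyl on this core leaves the number within the scatter. Within the data shown here, this is the first measured step with a group as large as butyl and the first on a chain hanging from a double-bonded ring carbon; with a 1.6-fold lower number from compound 1 to compound 3 (0.19 log units; within the scatter), on a core where the chain hangs from an aromatic carbon, there are now two chain-lengthening steps, neither beyond the scatter. Nothing in hand explains why this position accepts the longer chain.

From the compounds shown here alone, whether a still longer chain, an amine or a carboxylic acid in place of butyl would also stay within the scatter of compound 2 remains open. Also open, going by these compounds, is whether butyl at the same place on the core of compound 3 would give a step of similar size.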